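Compound 1 to compound 4: a swap on nitrogen

The source may hold more compounds than are shown below. What is called first, only, known or untested is meant among the compounds shown, and "the series" means these compounds.

Measured so far in a functional assay on HOS-TE85 cells (Homo sapiens) for inhibition, read by CCK-8 assay, with a stated time of 72 h; a lower number here means a stronger inhibitor, a higher number a weaker inhibitor
- Compound 1 `COc1ccc(F)cc1N1C(=O)CSC1c1cccc(C(=O)NCCCCn2cccn2)c1` gives 97.3 nM
- Compound 2 `COc1ccc(F)cc1N1C(=O)CSC1c1cccc(C(=O)NCCCCc2ccccc2)c1` gives 8.8 nM
- Compound 3 `Cc1cccc(N2C(=O)CSC2c2cccc(C(=O)NCCCCc3ccccc3)c2)c1` gives 93.2 nM

Compound 1 lies within the scatter of compound 3, and the two share the weak end of this small set. The other end is reached by an 11-fold lower number from compound 1 to compound 2 (1.04 log units; beyond the scatter), a change on the chain that leaves the group at issue here untouched.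

Compound 4 `O=C(NCCCCn1cccn1)c1cccc(C2SCC(=O)N2c2cc(Cl)ccn2)c1` keeps that chain of compound 1 and alters one group: 4-chloropyridin-2-yl in place of 5-fluoro-2-methoxyphenyl on an amide-type nitrogen in a ring. Going by the values given here, the only measured step at this place is an 11-fold higher number from compound 2 to compound 3 (1.02 log units; beyond the scatter), where 5-fluoro-2-methoxyphenyl also left, though on the phenyl-ended chain. Among the compounds with values here, that single pair points towards a higher number in this assay, but no compound measured so far carries a ring with a hetero atom at this place, so the size stays uncertain. The expected change, smaller than that measured step, is a 3.1-fold higher number from compound 1 to compound 4 (0.49 log units; beyond the scatter). For compound 4 the estimated value is 300 nM, with an expected range from 70 nM to 1300 nM.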

Compound 4, half-maximal inhibitory concentration: 36.4 nM
The estimate for compound 4 lay 8.2-fold (0.92 log units) above the measured number; measured number below the stated range.
By their numbers in this assay, from the lowest: compound 2; then compound 4; then compounds 3 and 1 (each within the scatter of the next).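

In this assay, the swap on the amide-type nitrogen in a ring moved the number down, with a 2.7-fold lower number from compound 1 to compound 4 (0.43 log units; beyond the scatter). Going by these compounds alone, the only earlier step at this place, an 11-fold higher number from compound 2 to compound 3 (1.02 log units; beyond the scatter), went the other way, so the departure of 5-fluoro-2-methoxyphenyl does not by itself raise the number: the direction differs with the entering group, the chain, or both. A ring with a hetero atom is thus accepted at this place on the pyrazole-ended chain, and nothing shown explains why this step goes down.

The compounds shown do not separate the contribution of the ring nitrogen from that of the chlorine, which a plain pyridin-2-yl at this place would address. Also open, going by these compounds, is whether 4-chloropyridin-2-yl would lower the number on the phenyl-ended chain of compound 2 as well.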